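Swapping a Cyclopropyl for a Methylpyrazole: Expected Lipophilicity

This account rests on a few compounds, and the source may have more. Where it says the series, first, only, none or still open, it means among the compounds named here.

Compound 1 `CN1CCN(CCCS(=O)(=O)c2ccc3nc(NC(=O)NC(=O)c4cc(C5CC5)ccc4Cl)sc3c2)CC1` — 2.9
Compound 2 `CS(=O)(=O)c1ccc2sc(NC(=O)NC(=O)c3ccccc3Cl)nc2c1` — 2.8
Compound 3 `COc1cc(Cl)c(C(=O)NC(=O)Nc2nc3ccc(S(=O)(=O)CCCN4CCN(C)CC4)cc3s2)cc1-n1cccn1` — 2.2

These three compounds were measured in a physicochemical assay for lipophilicity; on this read-out lower numbers stand for lower lipophilicity and higher numbers for higher lipophilicity. Compound 1 holds the highest of the three numbers; compound 2 sits a little lower, within the scatter, while compound 3 lies clearly lower, beyond the scatter. Compound 4 `Cc1ccn(-c2ccc(Cl)c(C(=O)NC(=O)Nc3nc4ccc(S(=O)(=O)CCCN5CCN(C)CC5)cc4s3)c2)n1` has not yet been measured. It differs from compound 1 in one place: 3-methyl-1H-pyrazol-1-yl in place of cyclopropyl on an aromatic carbon. Among the measured compounds shown here, no measured pair shows this same change, so its size is not known from these data. A modest downward step in this assay is expected, because compound 3, which also carries a five-membered aromatic ring with 2 hetero atoms, gives 2.2. The estimated step is a number 0.40 log units lower from compound 1 to compound 4 (beyond the scatter), a fall somewhat beyond the scatter. Compound 4 is therefore expected to give 2.5, between 2.1 and 2.9.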

Compound 4, distribution coefficient: 2.6
Compound 4: middle estimate off by 0.10 log units, on the low side; the range from low to high includes it.
By their numbers in this assay, from the lowest: compound 3; then compounds 4, 2 and 1 (each within the scatter of the next).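

In this assay, the swap of cyclopropyl for 3-methyl-1H-pyrazol-1-yl on this aromatic carbon now has a directly measured size: a number 0.30 log units lower from compound 1 to compound 4 (within the scatter). So at this place, para to the chloro group, a three-membered carbon ring can give way to a five-membered aromatic ring with 2 hetero atoms without a step that stands clear of the scatter. Nothing measured here explains the size of this step.

The compounds shown leave open how 1H-pyrazol-1-yl without the methyl, an amine or a carboxylic acid would read at this same place.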